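A ring group exchanged: what stability to expect?

This account rests on a few compounds, and the source may have more. Where it says the series, first, only, none or still open, it means among the compounds named here.

- Compound 1 `COc1ccccc1-n1nc(C2C[C@H](C)O[C@@H](C)C2)cc1-c1ccc(Cl)cc1`: 14%
- Compound 2 `COc1ccccc1-n1nc([C@@H]2CCO[C@@H](C(C)C)C2)cc1-c1ccc(Cl)cc1`: 14%

Both values come from an ADME assay on microsomes from liver (Rattus norvegicus) for metabolic stability, with a stated time of 10 min; on this read-out lower numbers stand for a less stable compound and higher numbers for a more stable compound. Within the data shown here, on this read-out, compound 2 stands at 14%, level with compound 1, the only other compound measured so far. The next compound, compound 3 `COc1ccccc1-n1nc(C2=CC(C)(C)OC(C)(C)C2)cc1-c1ccc(Cl)cc1`, has not yet been measured. It keeps the shared core but carries a different group on the same aromatic carbon: a group of 10 heavy atoms (9 carbon, 1 oxygen; one six-membered non-aromatic ring with 1 hetero atom) in place of a group of 9 heavy atoms (8 carbon, 1 oxygen; one six-membered non-aromatic ring with 1 hetero atom), on an aromatic carbon. The entering group also holds 1 double bond outside aromatic rings.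

Among the measured compounds shown here, only one measured step bears on this exchange: no change at the digits printed from compound 1 to compound 2 (within the scatter), with 2-isopropyloxan-4-yl in place of 2,6-dimethyloxan-4-yl. That single step gives thin evidence, and it involved no double bond. Even so, it offers no reason to expect a shift beyond the scatter in this assay, in either direction. The expected step is a number 3 percentage points higher from compound 2 to compound 3 (within the scatter). For compound 3 the estimated value is 17%, with an expected range of 7% to 38%.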

Compound 3, percent of the compound remaining: 37%
Compound 3: the middle estimate sits 20 percentage points below what was measured; the range from low to high includes it.
By their numbers in this assay, from the lowest: compounds 1 and 2 (each within the scatter of the next); then compound 3.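

Replacing 2-isopropyloxan-4-yl with the new ring on this aromatic carbon gives a number 23 percentage points higher from compound 2 to compound 3 (beyond the scatter) in this assay, and replacing 2,6-dimethyloxan-4-yl with it gives a number 23 percentage points higher from compound 1 to compound 3 (beyond the scatter) on the same read-out. Among these compounds, the earlier exchange between two rings without a double bond outside aromatic rings left the number level, so only this change shows that the group at this position can alter the result. The data hold no measurement that accounts for the rise.

The new ring differs from both earlier rings in its double bond, its size and its lack of defined stereocentres, and these compounds cannot separate those features. The same ring without its double bond would test that feature alone, while a piperidine ring would show what follows when nitrogen replaces the ring oxygen.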